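Three level sulfonamides and a 2,4-dimethylphenyl change

The compounds below may be only part of what the source reports. "The series", "measured", "known", "first", "only" and "open" are said of these compounds alone.

In a functional assay on M21 cells (Homo sapiens) for antiproliferative activity, read by sulforhodamine B assay, with a stated time of 48 h (on this read-out lower numbers stand for stronger inhibition and higher numbers for weaker inhibition), compound 1 (`Cc1cccc(NS(=O)(=O)c2ccc(N3CCNC3=O)cc2)c1`) gives 69 nM and compound 2 (`CCc1cccc(NS(=O)(=O)c2ccc(N3CCNC3=O)cc2)c1`) gives 82 nM while compound 3 (`O=C1NCCN1c1ccc(S(=O)(=O)Nc2ccc(Cl)cc2)cc1`) gives 90 nM under the same conditions. Compound 3 therefore stands level with the other two, and a 1.2-fold higher number from compound 1 to compound 2 (0.07 log units; within the scatter) shows the same for the remaining pair. The next structure is compound 4 (`Cc1ccc(NS(=O)(=O)c2ccc(N3CCNC3=O)cc2)c(C)c1`), reached through 2,4-dimethylphenyl in place of 4-chlorophenyl on a sulfonamide nitrogen with 2,4-dimethylphenyl in place of 4-chlorophenyl on a sulfonamide nitrogen. Two measured steps changed the group at that same place: a 1.3-fold higher number from compound 1 to compound 3 (0.12 log units; within the scatter) and a 1.1-fold higher number from compound 2 to compound 3 (0.04 log units; within the scatter) are both small. Among the measured compounds shown here, none of the three measured compounds carries 2,4-dimethylphenyl, so the data offer no direct precedent and the expectation rests on these small steps alone. An expected 1.1-fold higher number from compound 3 to compound 4 (0.05 log units; within the scatter) is the estimate here, so no shift beyond the scatter is foreseen. For compound 4 the estimated value is 100 nM with an expected range from 40 nM to 250 nM in this assay once it is measured.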

Compound 4, half-maximal inhibitory concentration: 150 nM
Compound 4: middle estimate off by 1.5-fold (0.18 log units), on the low side; the measured number falls inside the stated range.
By their numbers in this assay, from the lowest: compounds 1, 2, 3 and 4 (each within the scatter of the next, the first and the last beyond it).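

At the sulfonamide nitrogen, 2,4-dimethylphenyl gives the first step beyond the scatter among these compounds, a 2.2-fold higher number from compound 1 to compound 4 (0.34 log units; beyond the scatter) in this assay, though the step is modest. Compounds 2 and 3 do not share this separation, with a 1.8-fold higher number from compound 2 to compound 4 (0.26 log units; within the scatter) and a 1.7-fold higher number from compound 3 to compound 4 (0.22 log units; within the scatter), so compound 4 stands apart from compound 1 alone. No measurement here bears on why this step differs from the others at this place.

On these data alone, the two methyl groups of 2,4-dimethylphenyl change together in compound 4, so their separate contributions remain open. Every group on the sulfonamide nitrogen here is a phenyl ring carrying methyl, ethyl or chlorine, which leaves open how a methoxyphenyl, an aminophenyl or a saturated cyclohexyl ring would read at this place.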